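This account rests on a few compounds, and the source may have more. Where it says the series, first, only, none or still open, it means among the compounds named here.

In a functional assay on HT-29 cells (Homo sapiens) (on this read-out lower numbers stand for an effect already at smaller amounts and higher numbers for an effect only at larger amounts of compound), compound 1 `CS(=O)(=O)Nc1ccc(-c2cc(C(=O)N[C@H]3CCCNC3)c(NC(N)=O)s2)cc1` gives 2200 nM.
In this assay compound 2 `NC(=O)Nc1sc(-c2ccccc2)cc1C(=O)NC1CCOCC1` has "not determined" (no result reported).

The account rests on a single number. Among the measured compounds shown here, compound 1 is the only compound with a result in this assay; compound 2 shares the core of compound 1 but carries no result, so it offers no comparison, and no pair of measured compounds differing in one place is available. Compound 1 therefore stands alone at 2200 nM, neither strong nor weak by any shown comparison.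

Compound 3 `NC(=O)Nc1sc(-c2ccc(C(=O)N3CCCCC3)cc2)cc1C(=O)N[C@H]1CCCNC1` keeps the core of compound 1 and differs in one place: (piperidin-1-yl)carbonyl in place of methanesulfonamido on an aromatic carbon. The group that leaves is methanesulfonamido; the group that enters is (piperidin-1-yl)carbonyl, sitting on an aromatic carbon of a six-membered aromatic ring of carbon only, para to a large group. For the measured compounds named here, no measured step of this kind exists here, so the direction of the change cannot be read from the data. The step from compound 1 to compound 3 is expected to stay within the scatter, a 1.1-fold lower number from compound 1 to compound 3 (0.04 log units; within the scatter). Compound 3 is estimated at 2000 nM, with a range from 500 nM to 8000 nM.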

Compound 3, half-maximal effective concentration: 130 nM
For compound 3 the middle estimate is 15-fold (1.19 log units) above the measured one; the whole stated range lies above it.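

Among the compounds shown here, the exchange of methanesulfonamido for (piperidin-1-yl)carbonyl on an aromatic carbon, para to a large group, gives the first measured step in this assay, a 17-fold lower number from compound 1 to compound 3 (1.23 log units; beyond the scatter), which shows that the read-out responds strongly to the group at this position. The change alters several things at once: the entering group brings a six-membered non-aromatic ring and has no hydrogen-bond donors, while the leaving group has no ring and has one donor, so this single step cannot separate the contribution of any one of these features. No measurement of any property of these groups bears on the size of the step.

The compounds shown leave open whether the piperidine ring, the carbonyl or the absence of the sulfonamide hydrogen carries the step. They also leave open how a dimethylamide, a morpholine amide, a carboxylic acid or an open-chain amine would read at this same position on the shared core.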